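Working notes: from compound 3 to compound 4

This account rests on a few compounds, and the source may have more. Where it says the series, first, only, none or still open, it means among the compounds named here.

Measured in a functional assay on HeLa cells (Homo sapiens) for cytotoxicity, read by MTT assay, with a stated time of 72 h; on this read-out higher numbers stand for weaker inhibition and lower numbers for stronger inhibition:
- compound 1 `Nn1c(SCc2ccccc2[N+](=O)[O-])nnc1-c1c[nH]c2ccccc12`: 2520 nM
- compound 2 `Nn1c(SCc2ccc(F)cc2)nnc1-c1c[nH]c2ccccc12`: 290 nM
- compound 3 `Nn1c(SCc2ccc(Br)cc2)nnc1-c1c[nH]c2ccccc12`: 8000 nM

Compound 3 has the highest number of the three, and its gaps to both others lie beyond the scatter. The next compound is compound 4 `COc1ccc(CSc2nnc(-c3c[nH]c4ccccc34)n2N)cc1`, with methoxy in place of bromo on an aromatic carbon. Going by the values given here, one measured step bears on this place: a 28-fold higher number from compound 2 to compound 3 (1.44 log units; beyond the scatter), large and beyond the scatter. Among the compounds with values here, no methoxy compound has been measured, so only a moderate step towards a lower number in this assay is expected, smaller than that one. The expected change is a 4.0-fold lower number from compound 3 to compound 4 (0.60 log units; beyond the scatter). For compound 4 the estimated value is 2000 nM, with an expected range of 400 nM to 9000 nM.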

Compound 4, half-maximal inhibitory concentration: 750 nM
Compound 4: middle estimate off by 2.7-fold (0.43 log units), on the high side, within the range that was stated.
By their numbers in this assay, from the lowest: compound 2; then compound 4; then compound 1; then compound 3.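

In this assay, the high number at this position is not shared by methoxy, which gives an 11-fold lower number from compound 3 to compound 4 (1.03 log units; beyond the scatter) as a large step. Methoxy does not match fluoro, however, with a 2.6-fold higher number from compound 2 to compound 4 (0.41 log units; beyond the scatter) as a modest step, so the three groups at this position stand at three separate levels. No supporting data explain these differences. Going by these compounds, it remains open whether an amine or a carboxylic acid at this position would sit near the level of compound 2, compound 4 or compound 3.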